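This account rests on a few compounds, and the source may have more. Where it says the series, first, only, none or still open, it means among the compounds named here.

Working notes on the amidine series.

Compound 1 `C[C@@]1(c2cc(NC(=O)c3coc(C(F)F)n3)ccc2F)C=C(CF)OC(N)=N1` is the reference for this step. Among the measured compounds shown here, in an ADME assay on microsomes from liver (Rattus norvegicus, strain Crj;CD(SD)) for metabolic stability, read by LC-MS, using NADPH, with a stated time of 30 min, tested at 0.1 uM (a lower number here means that less of the compound is left, a higher number that more of the compound is left), compound 1 gives 57%, which is the highest of the two numbers measured so far. For the measured compounds named here, compound 2 `COc1cnc(C(=O)Nc2ccc(F)c([C@]3(C)C=C(CF)OC(N)=N3)c2)cn1` is the only other measured member; in this assay compound 2 gives 13%. Going by the values given here, the one measured step, a number 44 percentage points lower from compound 1 to compound 2 (beyond the scatter), exchanges the group on the carbonyl carbon for a six-membered aromatic ring bearing a methoxy group.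

Compound 3 `COc1cc(C#N)cnc1C(=O)Nc1ccc(F)c([C@]2(C)C=C(CF)OC(N)=N2)c1` has not yet been measured. Compared with compound 1 it differs as follows: 5-cyano-3-methoxypyridin-2-yl in place of 2-(difluoromethyl)-1,3-oxazol-4-yl on a carbonyl carbon. The change again replaces the five-membered ring on the carbonyl carbon with a six-membered aromatic ring carrying a methoxy group, here with a nitrile added. Among the compounds with values here, the step from compound 1 to compound 2 is the only measured step that bears on this, and it was large and beyond the scatter. On that basis a large downward step, a number 37 percentage points lower from compound 1 to compound 3 (beyond the scatter), is expected in this assay; compound 3 is estimated at 20%, with a range from 8% to 40%. Within the data shown here, the nitrile has no precedent in the measured set, so the range is kept wide.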

Compound 3, percent of the compound remaining: 60%
Beside the measured number, compound 3's estimate is 40 percentage points below it; measured number outside the range, above it.
By their numbers in this assay, from the lowest: compound 2; then compounds 1 and 3 (each within the scatter of the next).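

The result, a number 3 percentage points higher from compound 1 to compound 3 (within the scatter), in this assay, shows that a six-membered aromatic ring carrying a methoxy group on the carbonyl carbon does not by itself go with a low number, since 5-cyano-3-methoxypyridin-2-yl and 2-(difluoromethyl)-1,3-oxazol-4-yl cannot be told apart here. Between the two six-membered groups the exchange gives a number 47 percentage points higher from compound 2 to compound 3 (beyond the scatter), so among the three compounds the low number stands with 5-methoxypyrazin-2-yl alone and not with ring size as such. Nothing at hand gives a reason for either step.

Open, going by these compounds, is whether the nitrile or the rest of 5-cyano-3-methoxypyridin-2-yl carries the step from the 5-methoxypyrazin-2-yl compound, a question that a plain 3-methoxypyridin-2-yl group, or an amine in place of the nitrile, would help to separate. Also open, on these data alone, is how far these readings hold when other parts of the molecule change, as all three compounds share the core of compound 1 and vary only in the group on the carbonyl carbon.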